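Propanoyl to vinylcarbonyl on the trimethoxyphenyl benzylamide series

The compounds below may be only part of what the source reports. "The series", "measured", "known", "first", "only" and "open" are said of these compounds alone.

Measured so far:
compound 1 `CCC(=O)N(Cc1ccc(OC)c(O)c1)c1cc(OC)c(OC)c(OC)c1` gives 98 nM in a functional assay on KYSE-450 cells (Homo sapiens) for inhibition, read by MTT assay, with a stated time of 48 h; on this read-out lower numbers stand for stronger inhibition and higher numbers for weaker inhibition
compound 2 `COC(=O)c1cc(CNc2cc(OC)c(OC)c(OC)c2)ccc1OC` gives 41100 nM
compound 3 `COc1ccc(CNc2cc(OC)c(OC)c(OC)c2)cc1` gives 4890 nM

Compound 1 holds the lowest number of the three, with compound 3 next and compound 2 furthest away. Among the measured compounds shown here, the one measured step, an 8.4-fold lower number from compound 2 to compound 3 (0.92 log units; beyond the scatter), concerns hydrogen in place of methoxycarbonyl on an aromatic carbon and does not touch the amide.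

Compound 4 `C=CC(=O)N(Cc1ccc(OC)c(O)c1)c1cc(OC)c(OC)c(OC)c1` differs from compound 1 in vinyl in place of ethyl on a carbonyl carbon. For the measured compounds named here, no measured step bears on a change at the carbonyl carbon, so there is no basis for expecting a shift in this assay beyond the scatter in either direction. Compound 4 is therefore estimated to land close to compound 1, at 80 nM with a range of 30 nM to 250 nM, meaning an expected step of a 1.2-fold lower number from compound 1 to compound 4 (0.09 log units; within the scatter).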

Compound 4, half-maximal inhibitory concentration: 160 nM
Compound 4: middle estimate off by 2.0-fold (0.30 log units), on the low side; low and high end bracket the measured number.
By their numbers in this assay, from the lowest: compounds 1 and 4 (each within the scatter of the next); then compound 3; then compound 2.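

In this assay, among the compounds shown here, the first measured change at the carbonyl carbon, vinyl in place of ethyl, gives a 1.6-fold higher number from compound 1 to compound 4 (0.21 log units; within the scatter) and so leaves the two compounds indistinguishable on this read-out. This position therefore accepts a double bond outside aromatic rings without a step beyond the scatter, at least for this one pair. No measurement on hand accounts for this result.

Still open, going by these compounds, is how a longer chain, a cyclopropyl group or a dimethylamino group on the carbonyl carbon would read. Also open, on these data alone, is whether vinyl and ethyl stay this close on other cell lines.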